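A Dichlorophenyl Swap Measured Against a Ceiling of Limits

A few compounds are considered here, and "the series" means these few. Any claim that something is new, unique, unknown or untested is made for them only; others in the source may bear on it.

Compound 1 `N#CC1=C(N)Oc2c(c3nc4ccccc4nc3c3ccccc23)C12C(=O)N(Cc1cnnn1-c1ccc(F)cc1)c1ccccc12` — in a functional assay on HepG2 cells (Homo sapiens) for antiproliferative activity, read by MTT assay, with a stated time of 48 h (a higher number here means a weaker inhibitor, a lower number a stronger inhibitor), compound 1 reaches only the assay limit > 50000 nM.
Compound 2 `N#CC1=C(N)Oc2c(c3nc4ccccc4nc3c3ccccc23)C12C(=O)N(Cc1cnnn1-c1ccc(Cl)c(Cl)c1)c1ccccc12` — in this assay compound 2 reaches only the assay limit > 50000 nM.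
Compound 3 `Cc1ccccc1-n1nncc1CN1C(=O)C2(C(C#N)=C(N)Oc3c(N)cc4nc5ccccc5nc4c32)c2ccccc21` — in this assay compound 3 reaches only the assay limit > 50000 nM.

Compound 3 therefore stands where every measured compound stands: at a limit, not a number (the limit of > 50000 nM in this assay, at which 3 of the 3 values shown sit). Compound 4 `N#CC1=C(N)Oc2c(N)cc3nc4ccccc4nc3c2C12C(=O)N(Cc1cnnn1-c1ccc(Cl)cc1Cl)c1ccccc12` differs from compound 3 by 2,4-dichlorophenyl in place of 2-methylphenyl on an aromatic nitrogen. Among the compounds with values here, the one measured step, a step that the two limits leave unreadable from compound 1 to compound 2, also exchanges a halogenated phenyl on an aromatic nitrogen, yet its size cannot be read because both ends sit at the limit (the limit of > 50000 nM in this assay, at which 3 of the 3 values shown sit). No readable step bears on the change, so no movement beyond the scatter is expected in this assay. Compound 4 is estimated at 60000 nM, between 20000 nM and 200000 nM. The expected step that the limit leaves unreadable from compound 3 to compound 4 thus means no change that the assay can resolve.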

Compound 4, half-maximal inhibitory concentration: > 50000 nM
Compound 4 was reported as a limit (the forecaster's own chance of this, stated with the estimate: 85%); the middle value is on the limit's open side.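

The step between compound 3 and compound 4 cannot be read, because both ends are limits: the limit of > 50000 nM in this assay, at which 4 of the 4 values shown sit. In this assay the compounds shown leave open which change, if any, would give a number rather than a limit.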